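The source may report more compounds than this note shows. Statements on the series, on what has been measured and on what is new or still open speak of the compounds shown alone.

In an ADME assay on MOLT-3 cells (Homo sapiens) for cytotoxicity, with a stated time of 7 days (a higher number here means that more compound is tolerated, a lower number that less compound is tolerated), compound 3 `CC(C)CNc1nc(N)nc2c1ncn2/C=C1/CC1(CO)CO` has no single number and stands at "not determined" (no result reported). Compound 2 `Nc1nc(N2CCCC2)c2ncn(/C=C3/CC3(CO)CO)c2n1` gives no number either, standing at "not determined" (no result reported). Compound 1 `COCCOc1nc(N)nc2c1ncn2/C=C1/CC1(CO)CO` gives > 20000 nM, which is a limit of the assay and not a number. The move from compound 3 to compound 4 `CCCCCCOc1nc(N)nc2c1ncn2/C=C1/CC1(CO)CO` puts hexyloxy in place of isobutylamino on an aromatic carbon, next to the ring nitrogen: hexyloxy in place of isobutylamino on an aromatic carbon. With no number for compound 3, the step cannot be sized from measurement. The only anchor is the limit of > 20000 nM in this assay, at which 1 of the 3 values shown sits, so a modest step in this assay towards less compound tolerated is expected. For compound 4 the estimated half-maximal cytotoxic concentration is 20000 nM, with an expected range of 7000 nM to 40000 nM.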

Compound 4, half-maximal cytotoxic concentration: > 20000 nM
Compound 4 was reported as a limit; the forecaster's own chance of this, stated with the estimate: 60%; the middle value lies on the limit itself.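

No step can be read from compound 1 to compound 4, since both are reported only as limits: the limit of > 20000 nM in this assay, at which 2 of the 4 values shown sit.

The compounds shown leave open whether this change shifts the half-maximal cytotoxic concentration in this assay at all.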